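Swapping 2,3,6-trifluorophenyl for 2,3-dihydroxyphenyl: working notes

A few compounds are considered here, and "the series" means these few. Any claim that something is new, unique, unknown or untested is made for them only; others in the source may bear on it.

Values in a functional assay on G-361 cells (Homo sapiens) for antiproliferative activity, with a stated time of 72 h; on this read-out higher numbers stand for weaker inhibition and lower numbers for stronger inhibition:
compound 1 `COc1cc(CNc2ncnc3c2ncn3[C@@H]2O[C@H](CO)[C@@H](O)[C@H]2O)cc(OC)c1`: "not determined" (no result reported)
compound 2 `OC[C@H]1O[C@@H](n2cnc3c(NCc4ccc(F)cc4F)ncnc32)[C@H](O)[C@@H]1O`: > 166000 nM
compound 3 `OC[C@H]1O[C@@H](n2cnc3c(NCc4c(F)ccc(F)c4F)ncnc32)[C@H](O)[C@@H]1O`: > 166000 nM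

Compound 3 stands at the limit of > 166000 nM in this assay, at which 2 of the 3 values shown sit, which is a limit and not a number. Compound 4 `OC[C@H]1O[C@@H](n2cnc3c(NCc4cccc(O)c4O)ncnc32)[C@H](O)[C@@H]1O` carries a new group on a saturated chain carbon bound to a nitrogen on an aromatic ring: 2,3-dihydroxyphenyl in place of 2,3,6-trifluorophenyl on a saturated chain carbon bound to a nitrogen on an aromatic ring. Among the measured compounds shown here, only one measured step bears on this change, a step that the two limits leave unreadable from compound 2 to compound 3, and it offers no size or direction to carry over. The estimate is therefore weakly founded, and a result at the same limit remains likely. Tentatively expected is an at least 2.3-fold lower number from compound 3 to compound 4 (0.37 log units; beyond the scatter), toward stronger inhibition. For compound 4 the estimated value is 70000 nM, with an expected range of 12000 nM to 200000 nM.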

Compound 4, half-maximal inhibitory concentration: 16900 nM
Compound 4: middle estimate off by 4.1-fold (0.62 log units), on the high side; low and high end bracket the measured number.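

In this assay, 2,3-dihydroxyphenyl on a saturated chain carbon bound to a nitrogen on an aromatic ring gives the only readable number among the compounds shown, and compound 2 and compound 3 each stop at a limit: the limit of > 166000 nM in this assay, at which 2 of the 4 values shown sit. Replacing 2,3,6-trifluorophenyl gives an at least 9.8-fold lower number from compound 3 to compound 4 (0.99 log units; beyond the scatter), and replacing 2,4-difluorophenyl gives an at least 9.8-fold lower number from compound 2 to compound 4 (0.99 log units; beyond the scatter). On these data alone, the true size of both steps stays open beyond these bounds, and the step between the two fluorinated compounds cannot be read.

The compounds shown do not separate the loss of fluorine from the gain of the hydroxyl groups. As far as these compounds go, whether one hydroxyl group alone, an amine or a carboxylic acid would give a similar number also stays open.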